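Hydroxy to methoxy on two related cores

The source may hold more compounds than are shown below. What is called first, only, known or untested is meant among the compounds shown, and "the series" means these compounds.

Measured so far:
compound 1, `COc1cc(/C=C/Cc2cc(O)c3ccsc3c2)cc(OC)c1OC`: 38700 nM
compound 2, `COc1cc(/C=C\Cc2cc(O)c3ccoc3c2)cc(OC)c1OC`: 49 nM
compound 3, `COc1cc(/C=C/Cc2cc(OC)c3ccsc3c2)cc(OC)c1OC`: 53000 nM

All numbers come from a functional assay on BMEC cells (Bos taurus) for antiproliferative activity; on this read-out higher numbers stand for weaker inhibition and lower numbers for stronger inhibition. Compound 1 and compound 3 differ by methyl in place of hydrogen on an oxygen on an aromatic ring; the step of a 1.4-fold higher number from compound 1 to compound 3 (0.14 log units; within the scatter) is within the scatter, so on this core the change leaves the number where it was. Compound 2 is built on a different core; the difference between the two cores is not broken down here. In this assay compound 2 gives the lowest of the three numbers, with compound 1 and compound 3 both far above it, beyond the scatter.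

Compound 4, `COc1cc(/C=C\Cc2cc(OC)c3ccoc3c2)cc(OC)c1OC`, has not yet been measured. It differs from compound 2 by methyl in place of hydrogen on an oxygen on an aromatic ring, the same change, at the same place, as from compound 1 to compound 3. Resting on the step of a 1.4-fold higher number from compound 1 to compound 3 (0.14 log units; within the scatter), the step from compound 2 to compound 4 in this assay is expected to be small, about a 2.2-fold higher number from compound 2 to compound 4 (0.35 log units; beyond the scatter), though it is made here from a much lower starting number. Compound 4 is accordingly estimated at 110 nM, between 35 nM and 600 nM.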

Compound 4, half-maximal inhibitory concentration: 7500 nM
The estimate for compound 4 lay 68-fold (1.83 log units) below the measured number; measured number above the stated range.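

On the core of compound 2, hydroxy to methoxy gives a 150-fold higher number from compound 2 to compound 4 (2.18 log units; beyond the scatter) in this assay and removes most of the inhibition seen with the free hydroxy. The flat step on the other core was therefore no guide to the size of the step here, and the change does not carry over between these cores: the same change on two cores in this assay, a 1.4-fold higher number (0.14 log units; within the scatter) from compound 1 to compound 3 and a 150-fold higher number (2.18 log units; beyond the scatter) from compound 2 to compound 4, 110-fold (2.05 log units) apart, beyond the scatter of two such steps

The comparison does not show which difference between the cores sets the two steps apart, and two pairs give no rule for any further core; the flat step also starts from a high number, with compound 1 at 38700 nM even with the hydroxy present.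

Still open, from the compounds shown here alone, is whether the loss on the core of compound 2 follows from replacing the hydrogen on that oxygen as such or from the added methyl. Ethoxy or acetoxy at the same place, or an amine in place of the hydroxy, would bear on this, and the separate contributions of the two cores remain unresolved.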